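From Iodo to Hydroxymethyl on a Shared Core

A few compounds are considered here, and "the series" means these few. Any claim that something is new, unique, unknown or untested is made for them only; others in the source may bear on it.

Of the compounds shown here, two have been measured in a functional assay on MCF7 cells (Homo sapiens) for cytotoxicity; on this read-out higher numbers stand for weaker inhibition and lower numbers for stronger inhibition. Compound 1 (`Nc1ccc(-c2nc3cc(O)ccc3s2)cc1`) gives > 100000 nM, which is a limit of the assay rather than an exact number. Compound 2 (`Nc1ccc(-c2nc3ccccc3s2)cc1I`) gives < 1 nM, which is also a limit, and it stands at the strong end of the two values. For the measured compounds named here, the two compounds differ in more than one place, so no measured step shows what a single change does.

The next compound, compound 3 (`Nc1ccc(-c2nc3ccccc3s2)cc1CO`), has hydroxymethyl in place of iodo on an aromatic carbon.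

Compound 2, at its limit of < 1 nM, leaves little room for measurable gain, so weakening is the likelier direction. The expected change is large but uncertain, an at least 300-fold higher number from compound 2 to compound 3 (2.47 log units; beyond the scatter). Compound 3 is estimated at 300 nM, with an expected range from 5 nM to 20000 nM.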

Compound 3, half-maximal inhibitory concentration: 6 nM
Compound 3: middle estimate off by 50-fold (1.70 log units), on the high side; the range from low to high includes it.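

For the compounds shown here, this is the first single change that can be read on the shared core: in this assay, hydroxymethyl in place of iodo, ortho to an amino group, gives an at least 6.0-fold higher number from compound 2 to compound 3 (0.77 log units; beyond the scatter). The change weakens the read-out, yet compound 3 still stands at 6 nM, so iodo is not needed at this position for a low number. The step can only be given as a minimum, because compound 2 sits at a limit of the assay: the limit of < 1 nM in this assay, at which 1 of the 3 values shown sits.

The compounds shown leave open whether a methyl group, a chlorine atom or a carboxylic acid at this position would keep the number low. Compound 1 differs from compound 2 and compound 3 in more than one place, so its steps to them cannot be read.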